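Removing the carbamate from a pyridylethynyl tetrahydropyridine

A few compounds are considered here, and "the series" means these few. Any claim that something is new, unique, unknown or untested is made for them only; others in the source may bear on it.

In an assay for displacement of a labelled ligand from metabotropic glutamate receptor 5 (Rattus norvegicus) (on this read-out higher numbers stand for weaker inhibition and lower numbers for stronger inhibition), compound 1 `O=C1c2ccccc2C(=O)N1C1C=C(C#Cc2ccccn2)CCC1` gives 5.8 nM and compound 2 `CC(C)(C)OC(=O)N1CC=C(C#Cc2ccccn2)CC1` gives 20 nM. Compound 2 thus holds the higher of the two numbers, and its gap to compound 1 lies beyond the scatter. Compound 3 `C(#Cc1ccccn1)C1=CCNCC1` differs from compound 2 by hydrogen in place of tert-butoxycarbonyl on an amine nitrogen in a ring. Going by the values given here, no measured pair shows such a step, so the expectation rests on the change alone: a rise in this assay is expected, of the size a 4.0-fold higher number from compound 2 to compound 3 (0.60 log units; beyond the scatter), with wide uncertainty. Compound 3 is therefore estimated at 80 nM, with a range from 15 nM to 600 nM.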

Compound 3, inhibition constant: 3400 nM
Compound 3: the middle estimate sits 43-fold (1.63 log units) below what was measured, and the stated range ends below it.
By their numbers in this assay, from the lowest: compound 1; then compound 2; then compound 3.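

Replacing tert-butoxycarbonyl with hydrogen on the ring nitrogen gives a 170-fold higher number from compound 2 to compound 3 (2.23 log units; beyond the scatter) in this assay, the first step read at this position. It shows that this nitrogen is far from indifferent to what it carries, and that the unsubstituted amine is not tolerated as well as the carbamate. Nothing at hand explains a rise of this size. The compounds shown leave open whether a small group such as methyl or acetyl on this nitrogen would restore the lower number, or whether the whole tert-butoxycarbonyl group is needed.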